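Removing the acetyl group from an indole-linked phenol

A few compounds are considered here, and "the series" means these few. Any claim that something is new, unique, unknown or untested is made for them only; others in the source may bear on it.

Measured compounds:
compound 1 `CC(=O)Oc1ccccc1-c1cc2ccccc2[nH]1` gives 31000 nM
compound 2 `O=C1c2ccccc2C(=O)N1c1ccccc1O` gives 916000 nM
compound 3 `Oc1ccccc1-c1c[nH]c2ccccc12` gives 95000 nM

These three numbers come from a functional assay on U-251 cells (Homo sapiens) for antiproliferative activity, read by sulforhodamine B assay, with a stated time of 72 h; a lower number here means that less compound is needed, a higher number that more compound is needed for the effect. Among them, compound 1 stands lowest: compound 3 sits somewhat higher, beyond the usual scatter, and compound 2 sits far higher still, so compound 1 is the strongest of the three measured here.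

The next compound, compound 4 `Oc1ccccc1-c1cc2ccccc2[nH]1`, has not yet been measured. It differs from compound 1 in one place: hydrogen in place of acetyl on an oxygen on an aromatic ring. Cut one bond further out, the same change reads acetoxy to hydroxy. For the measured compounds named here, nothing measured so far shows this exact change, so the expectation rests on the spread of the measured values alone.

The related hydroxy compound 3 gives 95000 nM, a higher number than compound 1, which hints that the free hydroxy may cost a little. The step of a 1.6-fold higher number from compound 1 to compound 4 (0.21 log units; within the scatter) is therefore expected to be small and upward, close to the scatter. In this assay, compound 4 is expected to give about 50000 nM, with a likely range from 15000 nM to 160000 nM.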

Compound 4, half-maximal effective concentration: 130000 nM
The estimate for compound 4 lay 2.6-fold (0.41 log units) below the measured number; measured number inside the range.
By their numbers in this assay, from the lowest: compound 1; then compounds 3 and 4 (each within the scatter of the next); then compound 2.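

In this assay, putting hydrogen in place of acetyl on the oxygen on the aromatic ring gives a 4.2-fold higher number from compound 1 to compound 4 (0.62 log units; beyond the scatter), so within this pair the acetoxy compound needs less compound for the effect than its hydroxy partner. For the compounds shown here, this is the first direct reading of the change, as the earlier compounds differ from one another in more than one place and could not isolate the acetyl group. Nothing measured here accounts for the size or direction of this step.

On these data alone, it remains open whether a methyl ether or a longer acyl chain such as butyryl on that oxygen would give a number closer to that of the acetoxy or the hydroxy compound. An amine in place of the hydroxy is equally untested by the compounds shown.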